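Changing the amine substituent on the shared core

A few compounds are considered here, and "the series" means these few. Any claim that something is new, unique, unknown or untested is made for them only; others in the source may bear on it.

Going by the values given here, compound 1 `CCN(CC(=O)NC[C@H]1O[C@H](OC)[C@@H](OS(=O)(=O)O)[C@@H](OS(=O)(=O)O)[C@@H]1OS(=O)(=O)O)C(=O)COS(=O)(=O)O` gives 174000 nM in an assay on isolated protein for binding affinity to fibroblast growth factor 1 (Homo sapiens), read by surface plasmon resonance (a lower number here means tighter binding, a higher number weaker binding), the highest of the two numbers measured so far. Compound 2 `CO[C@H]1O[C@H](CNC(=O)CN(Cc2ccccc2)C(C)=O)[C@@H](OS(=O)(=O)O)[C@H](OS(=O)(=O)O)[C@@H]1OS(=O)(=O)O` gives 140000 nM in this assay. Compound 3 `CO[C@H]1O[C@H](CNC(=O)CN(C(C)=O)C2CCCCC2)[C@@H](OS(=O)(=O)O)[C@H](OS(=O)(=O)O)[C@@H]1OS(=O)(=O)O` differs from compound 1 as follows: acetyl(cyclohexyl)amino in place of ethyl(((sulfooxy)methyl)carbonyl)amino on a saturated chain carbon bound to a carbonyl carbon. Among the compounds with values here, the only step that bears on this is a 1.2-fold lower number from compound 1 to compound 2 (0.09 log units; within the scatter), where a different group entered at the same place and the number stayed within the scatter. A similar outcome is expected here. Compound 3 is estimated at 140000 nM (range 60000 nM to 330000 nM), the expected step being a 1.2-fold lower number from compound 1 to compound 3 (0.09 log units; within the scatter), not beyond the scatter.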

Compound 3, dissociation constant: 310000 nM
Compound 3: the middle estimate sits 2.2-fold (0.35 log units) below what was measured, within the range that was stated.
By their numbers in this assay, from the lowest: compounds 2, 1 and 3 (each within the scatter of the next, the first and the last beyond it).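

Cyclohexyl in place of benzyl on an amide-type nitrogen gives a 2.2-fold higher number from compound 2 to compound 3 (0.35 log units; beyond the scatter), the only step among these compounds that passes the scatter. Acetyl(cyclohexyl)amino in place of ethyl(((sulfooxy)methyl)carbonyl)amino gives a 1.8-fold higher number from compound 1 to compound 3 (0.25 log units; within the scatter), so this larger exchange on a saturated chain carbon bound to a carbonyl carbon stays within the scatter. No evidence is available to explain either step.

On these data alone, whether an amine, a carboxylic acid or a longer chain in place of cyclohexyl on that nitrogen would move the number beyond the scatter in either direction remains open.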